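Styryl in place of hydroxyphenyl on the shared core

The source may hold more compounds than are shown below. What is called first, only, known or untested is meant among the compounds shown, and "the series" means these compounds.

Measured compounds and their values:
Compound 1, `N#CC1=C(N)N(c2ccc(S(N)(=O)=O)cc2)C2=C(CCCC2)C1c1ccccc1`, 5%
Compound 2, `Cc1ccc(C2C(C#N)=C(N)N(c3ccc(S(N)(=O)=O)cc3)C3=C2CCCC3)cc1`, 20%
Compound 3, `N#CC1=C(N)N(c2ccc(S(N)(=O)=O)cc2)C2=C(CCCC2)C1c1ccc(O)cc1`, 20%

In a functional assay on Ehrlich cells (Mus musculus) for cytotoxicity, read by trypan blue exclusion, with a stated time of 2 h, tested at 10 ug/mL (on this read-out higher numbers stand for a stronger effect at the one concentration tested and lower numbers for a weaker effect), compound 3 gives 20%. This is level with compound 2 at the digits shown, and the two stand together as the highest of the three numbers; compound 1 lies furthest from compound 3, as a number 15 percentage points higher from compound 1 to compound 3 (beyond the scatter) shows.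

Compound 4, `N#CC1=C(N)N(c2ccc(S(N)(=O)=O)cc2)C2=C(CCCC2)C1/C=C/c1ccccc1`, has not yet been measured. It differs from compound 3 in one place: 2-phenylethenyl in place of 4-hydroxyphenyl on a saturated ring carbon.

The measured steps all concern the aromatic ring that now leaves. a number 15 percentage points higher from compound 1 to compound 2 (beyond the scatter) and a number 15 percentage points higher from compound 1 to compound 3 (beyond the scatter) were both modest, and no change at the digits printed from compound 2 to compound 3 (within the scatter) lay within the scatter, so swapping one substituent on that ring for another made no visible difference, while adding a substituent to bare phenyl raised the number modestly. None of these steps covers exchanging the whole ring for a 2-phenylethenyl group, so the expectation for compound 4 is uncertain. Compound 4 is expected to stay within the scatter of compound 3, with the step of a number 5 percentage points lower from compound 3 to compound 4 (within the scatter) estimated to be small. The estimate for compound 4 in this assay is 15%, with a range from 5% to 30%.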

Compound 4, a percentage reported as activity, at one concentration (the size of the read-out at that concentration, not a potency): 50%
The estimate for compound 4 lay 35 percentage points below the measured number; the measured number lies above the stated range.
By their numbers in this assay, from the lowest: compound 1; then compounds 2 and 3 (each within the scatter of the next); then compound 4.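

In this assay, exchanging the whole group on the saturated ring carbon gave a number 30 percentage points higher from compound 3 to compound 4 (beyond the scatter), and the same kind of exchange gave a number 30 percentage points higher from compound 2 to compound 4 (beyond the scatter) and a number 45 percentage points higher from compound 1 to compound 4 (beyond the scatter). The earlier compounds shown here showed only what substituents on the aromatic ring do at this position, and replacing that directly attached ring with 2-phenylethenyl, which keeps an aromatic ring and brings in a double bond outside it, moved the number further than any of those substitutions did. Nothing available explains this rise, so the change can be described here but not accounted for.

The compounds shown leave open whether the gain depends on the double bond itself, which a saturated 2-phenylethyl group on the same carbon would test, and whether a hydroxy or methyl group on the phenyl ring of 2-phenylethenyl would raise the number further, as these groups did on the phenyl ring of compound 1. As far as these compounds go, each number is also the size of the effect at a single concentration, so how the four compounds compare in potency remains open.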